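Cytotoxicity notes: benzyl variation on the imidazole arm

This account rests on a few compounds, and the source may have more. Where it says the series, first, only, none or still open, it means among the compounds named here.

Measured so far in a toxicity assay on NIH3T3 cells (Mus musculus) for cytotoxicity, read by resazurin assay; on this read-out higher numbers stand for an effect only at larger amounts of compound and lower numbers for an effect already at smaller amounts:
- compound 1 `COC(=O)c1ccc(NCc2cncn2Cc2ccccc2C(C)(C)C)cc1-c1ccccc1`: "not determined" (no result reported).
- compound 2 `CNC(=O)c1ccc(NCc2cncn2Cc2ccc(-c3ccccc3)cc2N)cc1-c1ccccc1`: > 1000 nM.
- compound 3 `c1ccc(-c2ccc(Cn3cncc3CNc3ccc(-c4onc5ccccc45)c(-c4ccccc4)c3)cc2)cc1`: > 10000 nM.

Compound 1 has no number in this assay, so its standing rests on the two neighbours. The value of compound 2 is a limit of this assay, not a number, as the limit of > 1000 nM in this assay, at which 1 of the 3 values shown sits, records. The value of compound 3 is likewise a limit, as the limit of > 10000 nM in this assay, at which 1 of the 3 values shown sits, records. Both members of the series that were tested therefore show no cytotoxic effect up to the highest amount that was run, and nothing in these values separates them from each other.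

Compound 4 `COC(=O)c1ccc(NCc2cncn2Cc2ccc(Br)cc2)cc1-c1ccccc1` is the next member to go into this assay. It differs from compound 1 by 4-bromophenyl in place of 2-(tert-butyl)phenyl on a saturated chain carbon bound to an aromatic nitrogen. For the measured compounds named here, the three measured compounds carry differently substituted aromatic groups at that same place yet none gave a number, so no step of any direction beyond the scatter is expected in this assay for compound 4; the most likely outcome is another limit.

Compound 4 is expected to give about 10000 nM in this assay, estimated between 2000 nM and 50000 nM.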

Compound 4, half-maximal effective concentration: > 10000 nM
Compound 4: only a limit was reported (the forecaster's own chance of this, stated with the estimate: 70%); the middle value lies on the limit itself.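

In this assay compound 4 gives > 10000 nM, a limit of the assay and not a number. For the compounds shown here, compound 1 has no number, so no step between compound 1 and compound 4 can be read. The compounds shown leave open at what amount, if any, the 4-bromobenzyl or 2-(tert-butyl)benzyl group would show a cytotoxic effect.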